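A few compounds are considered here, and "the series" means these few. Any claim that something is new, unique, unknown or untested is made for them only; others in the source may bear on it.

Of the compounds shown here, three built on one shared core have been tested in a functional assay on HeLa cells (Homo sapiens) for cytotoxicity, read by WST assay, with a stated time of 48 h; a lower number here means a stronger inhibitor, a higher number a weaker inhibitor. In this test, compound 1 `COc1cccc([C@@H]2OC[C@H]([C@@H](O)c3ccc(OC)c(OC)c3)C[C@H]2C/C=C/c2ccc(OC)c(OC)c2)c1` gives 30100 nM, compound 2 `COc1ccc(CCC[C@H]2C[C@@H]([C@@H](O)c3ccc(OC)c(OC)c3)CO[C@@H]2c2ccc(OC)c(OC)c2)cc1OC` gives 37700 nM, and compound 3 `Oc1ccccc1/C=C/C[C@H]1C[C@@H]([C@@H](O)c2ccccc2)CO[C@@H]1c1ccccc1` gives 21800 nM. These numbers all lie within the usual scatter of one another, so compound 3 stands level with the other two and cannot be ranked against them.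

The next compound to be tested is compound 4 `C=CC[C@H]1C[C@@H]([C@@H](O)c2ccccc2)CO[C@@H]1c1ccccc1`, a smaller relative of compound 3: vinyl in place of 2-(2-hydroxyphenyl)ethenyl on a saturated chain carbon bound to a saturated ring carbon. In words, this places vinyl in place of 2-(2-hydroxyphenyl)ethenyl on a saturated chain carbon bound to a saturated ring carbon. All three tested compounds keep an aromatic ring on that chain, so the data offer no direct view of what losing it does.

The close agreement between compound 1 at 30100 nM and compound 2 at 37700 nM, despite their different chains, gives no hint of a large effect. In this assay, a modest step towards a higher number, meaning a weaker inhibitor, is therefore expected, and it may not exceed the scatter. The expected change is a 1.6-fold higher number from compound 3 to compound 4 (0.21 log units; within the scatter). For compound 4, the estimated value is 35000 nM, with an expected range from 15000 nM to 90000 nM.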

Compound 4, half-maximal inhibitory concentration: 25400 nM
Compound 4: middle estimate off by 1.4-fold (0.14 log units), on the high side, and the stated range covers the measured number.
By their numbers in this assay, from the lowest: compounds 3, 4, 1 and 2 (each within the scatter of the next).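

In this assay, putting vinyl in place of 2-(2-hydroxyphenyl)ethenyl on a saturated chain carbon bound to a saturated ring carbon gives a 1.2-fold higher number from compound 3 to compound 4 (0.07 log units; within the scatter), the first direct view of this position without an aromatic ring on the chain. The aromatic ring, the hydrogen-bond donor and the hydrogen-bond acceptor all leave with the larger group, and the chain shrinks to a small vinyl, yet the two numbers stay level, so for this pair none of those features shows up as needed for the reading in this test. No measurement shown here offers an explanation for this outcome.

As far as these compounds go, what remains open is whether any group at this place can separate a compound from the level shared so far, for instance an amine, a carboxylic acid, or a longer saturated chain with no aromatic ring at its end. Because every step so far stays within the scatter, the compounds shown also leave open whether the other parts of the shared core matter more to this reading than this chain does.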